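The source may report more compounds than this note shows. Statements on the series, on what has been measured and on what is new or still open speak of the compounds shown alone.

Compounds measured in a functional assay on PANC-1 cells (Homo sapiens) for inhibition, read by MTT assay, with a stated time of 24 h; on this read-out lower numbers stand for stronger inhibition and higher numbers for weaker inhibition:
- compound 1, `CC1(C)[C@H]2CC[C@]1(C)N(Cc1cn(-c3ccc(F)cc3)nn1)C(=O)C2`: 110 nM
- compound 2, `CC1(C)[C@H]2CC[C@]1(C)N(Cc1cn(-c3ccccc3)nn1)C(=O)C2`: 160 nM

Going by the values given here, compound 1 has the lowest of the two numbers measured so far. Its nearest neighbour is compound 2, and the step between them, a 1.5-fold higher number from compound 1 to compound 2 (0.16 log units; within the scatter), lies within the scatter, so the two values cannot be told apart. Compound 3, `CC1(C)[C@H]2CC[C@]1(C)N(Cc1cn(-c3cccc(O)c3)nn1)C(=O)C2`, has not yet been measured in this assay. It differs from compound 1 in one place: 3-hydroxyphenyl in place of 4-fluorophenyl on an aromatic nitrogen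

Among the compounds with values here, only one measured step bears on this change, the one from compound 1 to compound 2, and it stayed within the scatter. It shows that altering the substituent on the aromatic ring attached to the ring nitrogen did not move the number beyond the usual spread. Within the data shown here, no measured pair speaks to a hydroxyl group on that ring, so the expectation rests on that single step alone. For compound 3 the expected step is a 1.5-fold higher number from compound 1 to compound 3 (0.16 log units; within the scatter), with wide uncertainty. Compound 3 is therefore estimated at about 160 nM in this assay, within a range from 60 nM to 450 nM.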

Compound 3, half-maximal inhibitory concentration: 280 nM
The estimate for compound 3 lay 1.8-fold (0.24 log units) below the measured number; the range from low to high includes it.
By their numbers in this assay, from the lowest: compounds 1, 2 and 3 (each within the scatter of the next, the first and the last beyond it).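

The earlier compounds had shown no step beyond the scatter at this position, so the group on the aromatic nitrogen could have seemed to matter little. In this assay, the exchange of 4-fluorophenyl for 3-hydroxyphenyl gives a 2.5-fold higher number from compound 1 to compound 3 (0.41 log units; beyond the scatter), which shows that the number can move at this position, though only modestly. The step that changes the hydroxy group alone gives a 1.8-fold higher number from compound 2 to compound 3 (0.24 log units; within the scatter), so the hydroxy group on its own cannot be told apart from hydrogen, and the difference is seen only when the two ends of the series are compared. The data offer no measured explanation for this difference.

The compounds shown leave open whether the modest step depends on where the hydroxy group sits, as 4-hydroxyphenyl would show, and whether it belongs to the hydroxy group at all, as a methoxy group or an amine at the same place on the phenyl ring would show. They also leave open how far the number would move if the phenyl ring itself gave way to a pyridine ring or a simple methyl group on the aromatic nitrogen.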